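The source may hold more compounds than are shown below. What is called first, only, known or untested is meant among the compounds shown, and "the series" means these compounds.

Measured compounds in a functional assay on CRL2813 cells (Homo sapiens) for cytotoxicity, read by sulforhodamine B assay, with a stated time of 5 days; on this read-out lower numbers stand for stronger inhibition and higher numbers for weaker inhibition:

Compound 1, `O=C(Nc1cccc(Cl)c1)N[C@H]1CC[C@H](Oc2ccc(F)cc2)CC1`, gives 5900 nM.
Compound 2, `O=C(Nc1ccc(Cl)cc1)N[C@H]1CC[C@H](Oc2ccc(F)cc2)CC1`, reaches only the assay limit, > 20000 nM, which is a limit and not a number.
Compound 3, `O=C(Nc1ccccc1I)N[C@H]1CC[C@H](Oc2ccc(F)cc2)CC1`, likewise sits at the assay limit, > 20000 nM, again a limit and not a number.

All three share the same core and differ only in the aryl group on the urea nitrogen. For the measured compounds named here, compound 1 is the only one with a readable number; the steps of an at least 3.3-fold higher number from compound 1 to compound 2 (0.53 log units; beyond the scatter) and an at least 3.3-fold higher number from compound 1 to compound 3 (0.53 log units; beyond the scatter) both show that the other two aryl groups give weaker inhibition, and the step that the two limits leave unreadable from compound 2 to compound 3 cannot be sized, since both compounds rest at the limit of > 20000 nM in this assay, at which 2 of the 3 values shown sit. Compound 3 therefore stands at the weak end of what has been seen, with no number of its own.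

Compound 4, `CSc1ccccc1NC(=O)N[C@H]1CC[C@H](Oc2ccc(F)cc2)CC1`, keeps everything of compound 3 except the change (methylsulfanyl in place of iodo on an aromatic carbon). Going by the values given here, no measured step involves methylsulfanyl, so only the position of the step from compound 1 to compound 3 offers guidance, and it points to weak inhibition at that place. The step from compound 3 to compound 4 is expected to be small, a number no higher from compound 3 to compound 4 (the limit leaves the size open), with compound 4 likely staying near the limit. Compound 4 is estimated at 20000 nM in this assay, within 7000 nM to 50000 nM.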

Compound 4, half-maximal inhibitory concentration: > 20000 nM
Compound 4: a limit, no number (the forecaster's own chance of this, stated with the estimate: 60%); the middle value sits exactly at the limit.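

In this assay, for the compounds shown here, the 2-(methylsulfanyl)phenyl group brings an at least 3.3-fold higher number from compound 1 to compound 4 (0.53 log units; beyond the scatter), so the 3-chlorophenyl group remains the only aryl group here with a readable number. Replacing iodo with methylsulfanyl puts two heavy atoms and one hydrogen-bond acceptor where one heavy atom and no acceptor stood, yet compound 4 gives > 20000 nM, which is a limit and not a number. This change therefore adds a third compound to the group at the limit, and the steps among compound 2, compound 3 and compound 4 cannot be read, since all three rest at the same limit: the limit of > 20000 nM in this assay, at which 3 of the 4 values shown sit.

The compounds shown leave open how weak these three really are, and so whether iodo and methylsulfanyl differ at all at this place on the aromatic ring. Also open, as far as these compounds go, is whether an amine or a carboxylic acid at this same place, or methylsulfanyl moved to the place that chlorine holds in compound 1, would give a readable number.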